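Cytotoxicity notes: benzyl replacement from compound 1 to compound 4

A few compounds are considered here, and "the series" means these few. Any claim that something is new, unique, unknown or untested is made for them only; others in the source may bear on it.

Compound 1 `COC(=O)c1ccc(NCc2cncn2Cc2ccccc2C(C)(C)C)cc1-c1ccccc1` carries no result in a toxicity assay on NIH3T3 cells (Mus musculus) for cytotoxicity, read by resazurin assay; a higher number here means that more compound is needed for the effect, a lower number that less compound is needed: its entry there reads "not determined" (no result reported). Two related compounds do carry readings, each a limit of the assay. Compound 2 `CNC(=O)c1ccc(NCc2cncn2Cc2ccc(-c3ccccc3)cc2N)cc1-c1ccccc1` gives in this assay the limit > 1000 nM. Compound 3 `Nc1cc(-c2ccccc2)ccc1Cn1cncc1CNc1ccc(-c2cncs2)c(-c2ccccc2)c1` gives in this assay the limit > 1000 nM. For the measured compounds named here, the one computed step between measured compounds, a step that the two limits leave unreadable from compound 2 to compound 3, therefore has no readable size. Overall, the limit of > 1000 nM in this assay, at which 2 of the 3 values shown sit, shows that no compound measured so far reaches a numeric value in this assay.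

Compound 4 `COC(=O)c1ccc(NCc2cncn2Cc2cccc(Cl)c2)cc1-c1ccccc1` differs from compound 1 by 3-chlorophenyl in place of 2-(tert-butyl)phenyl on a saturated chain carbon bound to an aromatic nitrogen. No measured step touches a change on the saturated chain carbon bound to an aromatic nitrogen, and the single step shown is unreadable, so no size or direction of change in this assay can be expected from the data beyond the pattern of limits. The value of compound 4 in this assay is estimated at 3000 nM, within 1000 nM to 10000 nM, with a strong chance that only a limit is again reported.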

Compound 4, half-maximal effective concentration: > 10000 nM
Compound 4: a limit, no number; the forecaster's own chance of this, stated with the estimate: 70%; middle value at least 3.3-fold (0.52 log units) from the limit.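

In this assay compound 1 reads "not determined" (no result reported). Compound 4 gives > 10000 nM, a limit and not a number, so no new step can be read from compound 1 to compound 4. The compounds shown leave open what 3-chlorobenzyl in place of 2-(tert-butyl)benzyl does in this assay, and whether any compound of the series reaches a numeric value there.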